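Amide nitrogen substituent series on a shared aryloxyacetamide core

A few compounds are considered here, and "the series" means these few. Any claim that something is new, unique, unknown or untested is made for them only; others in the source may bear on it.

Measured compounds in an assay on HEK293 cells for agonist activity at transient receptor potential cation channel subfamily M member 8 (Homo sapiens), read by fluorescence and calcium flux, with a stated time of 15 min; a lower number here means that less compound is needed, a higher number that more compound is needed for the effect:
- compound 1, `Cc1ccc(OCC(=O)N(CCCO)Cc2cccs2)cc1`, gives 3000 nM
- compound 2, `Cc1ccc(OCC(=O)N(Cc2cccs2)c2ccn(C)n2)cc1`, gives 855 nM
- compound 3, `COCCN(Cc1cccs1)C(=O)COc1ccc(C)cc1`, gives 400 nM

Compound 3 holds the lowest number of the three. The step of a 7.5-fold lower number from compound 1 to compound 3 (0.88 log units; beyond the scatter) and the step of a 2.1-fold lower number from compound 2 to compound 3 (0.33 log units; beyond the scatter) are both beyond the scatter, so compound 3 sits clearly ahead of compound 2 and compound 1 on the numbers shown; the step of a 3.5-fold lower number from compound 1 to compound 2 (0.55 log units; beyond the scatter) places compound 2 between the other two.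

Compound 4, `Cc1ccc(OCC(=O)N(Cc2cccs2)C(C)(C)C)cc1`, is not yet measured. Its change from compound 3 is tert-butyl in place of 2-methoxyethyl on an amide-type nitrogen. Among the measured compounds shown here, no measured step touches a substituent without a hydrogen-bond acceptor on this nitrogen, so none bears directly on it. The steps to compound 3 from compound 1 and from compound 2 were each modest, and all three substituents carry at least one acceptor. With that removed in compound 4, a modest step toward a higher number is expected, a 2.3-fold higher number from compound 3 to compound 4 (0.35 log units; beyond the scatter). Compound 4 is estimated at 900 nM, with a range from 250 nM to 3500 nM.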

Compound 4, half-maximal effective concentration: 11000 nM
Beside the measured number, compound 4's estimate is 12-fold (1.09 log units) below it, outside the stated range (above it).
By their numbers in this assay, from the lowest: compound 3; then compound 2; then compound 1; then compound 4.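

In this assay, among the compounds shown here, the step of a 28-fold higher number from compound 3 to compound 4 (1.44 log units; beyond the scatter) is the first large one in the set, and it comes with the heavy-atom count of the substituent on the amide-type nitrogen unchanged, so that count alone does not set the number at this position. The step of a 13-fold higher number from compound 2 to compound 4 (1.11 log units; beyond the scatter) is also large, while the step of a 3.7-fold higher number from compound 1 to compound 4 (0.56 log units; beyond the scatter) is modest but still beyond the scatter, which puts compound 4 above all three earlier compounds. Each of those three keeps at least one hydrogen-bond acceptor on this substituent, whereas tert-butyl has none and is also branched.

On these data alone, whether the higher number goes with the lost acceptor or with the branching stays open; an unbranched butyl chain and an isobutyl group on this nitrogen would separate the two. No measurement at hand explains the size of these steps.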